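A few compounds are considered here, and "the series" means these few. Any claim that something is new, unique, unknown or untested is made for them only; others in the source may bear on it.

Measured compounds:
Compound 1, `N#C/C=C/c1cc(F)c(Oc2nc(Nc3ccc(C#N)c(F)c3)nc3ccsc23)c(F)c1`: 96000 nM
Compound 2, `N#C/C=C/c1cc(F)c(Oc2nc(Nc3ccc(C#N)nc3)nc3ccsc23)c(F)c1`: 47500 nM
Compound 3, `Cc1cc(-c2ccc(C#N)cc2)cc(C)c1Oc1nc(Nc2ccc(C#N)c(F)c2)nc2sccc12`: > 254000 nM

In a toxicity assay on MT4 cells (Homo sapiens) for cytotoxicity, read by MTT assay, with a stated time of 5 days (on this read-out lower numbers stand for higher toxicity in this test and higher numbers for lower toxicity in this test), compound 1 gives 96000 nM. Compound 2 carries one change against compound 1, (6-cyanopyridin-3-yl in place of 4-cyano-3-fluorophenyl on a nitrogen on an aromatic ring), and in this assay compound 2 gives 47500 nM. The step is a 2.0-fold lower number from compound 1 to compound 2 (0.31 log units; beyond the scatter).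

Compound 3 is a different matter: its value in this assay is a limit of the assay and not a number, > 254000 nM. Within the data shown here, the only evidence on it is the limit of > 254000 nM in this assay, at which 1 of the 3 values shown sits. How the core of compound 3 differs from the core of compound 1 is not broken down here.

Compound 4, `Cc1cc(-c2ccc(C#N)cc2)cc(C)c1Oc1nc(Nc2ccc(C#N)nc2)nc2sccc12`, has not yet been measured in this assay. Against compound 3 it carries 6-cyanopyridin-3-yl in place of 4-cyano-3-fluorophenyl on a nitrogen on an aromatic ring, the same change that was made from compound 1 to compound 2, at a place described in the same words.

The step from compound 3 to compound 4 in this assay is expected to be an at least 1.4-fold lower number from compound 3 to compound 4 (0.14 log units; that floor lies within the scatter), resting on the measured step of a 2.0-fold lower number from compound 1 to compound 2 (0.31 log units; beyond the scatter). Compound 4 is therefore estimated at 180000 nM, with an expected range from 90000 nM to 400000 nM. With compound 3 reported only as a limit, a fair chance remains that compound 4 also comes back as a limit rather than a number.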

Compound 4, half-maximal cytotoxic concentration: 181000 nM
Compound 4: middle estimate off by 1.0-fold (0.00 log units), on the low side; measured number inside the range.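

In this assay, putting 6-cyanopyridin-3-yl in place of 4-cyano-3-fluorophenyl on the core of compound 3 gives an at least 1.4-fold lower number from compound 3 to compound 4 (0.14 log units; that floor lies within the scatter), which does not go against the direction seen on the core of compound 1, although that floor alone does not establish a real drop. Set side by side, the two steps can be compared only in part: the same change on two cores in this assay, a 2.0-fold lower number (0.31 log units; beyond the scatter) from compound 1 to compound 2 and an at least 1.4-fold lower number (0.14 log units; that floor lies within the scatter) from compound 3 to compound 4; the limit leaves it open whether they differ. As far as these compounds go, the value of compound 3, > 254000 nM, is a limit of the assay and not a number, and the true size of the second step therefore stays unknown, so one pair on each core does not show that the change carries over by a fixed amount.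

The compounds shown leave open whether the same change would give a lower number on any further core. They also leave open how this assay would read if a carboxylic acid or an amine replaced the nitrile on the ring attached to the nitrogen.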